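The source may report more compounds than this note shows. Statements on the series, on what has been measured and on what is new or still open speak of the compounds shown alone.

Compound 1 `CCOC(=O)c1c(-c2ccccc2)[nH]c2cc(OC)ccc2c1=O` carries the shared core with a plain phenyl group. In an ADME assay on HEK293 cells (Homo sapiens) for cytotoxicity, read by luminescence, with a stated time of 72 h (a higher number here means that more compound is needed for the effect, a lower number that less compound is needed), compound 1 gives > 22000 nM, which is a limit of the assay and not a number. Compound 2 `CCOC(=O)c1c(-c2cccc(F)c2)[nH]c2cc(OC)ccc2c1=O` gives > 22000 nM in this assay, again a limit. Compound 3 `CCOC(=O)c1c(-c2cccc(S(C)(=O)=O)c2)[nH]c2cc(OC)ccc2c1=O` gives > 22000 nM in this assay, also a limit. The step that the two limits leave unreadable from compound 1 to compound 2 therefore cannot be sized, nor can a step that the two limits leave unreadable from compound 1 to compound 3 or a step that the two limits leave unreadable from compound 2 to compound 3, because the limit of > 22000 nM in this assay, at which 3 of the 3 values shown sit, leaves nothing to compare. Compound 4 `CCOC(=O)c1c(-c2cccc(CO)c2)[nH]c2cc(OC)ccc2c1=O` is not yet measured; it differs from compound 1 by hydroxymethyl in place of hydrogen on an aromatic carbon. The three measured steps on the same aromatic carbon, with fluoro or methylsulfonyl entering, all sit at the limit, so no direction can be drawn from them for a hydroxymethyl group. Compound 4 is expected to remain at that limit as well, so the step that the limit leaves unreadable from compound 1 to compound 4 is expected to be nothing readable. Compound 4 is estimated at 40000 nM, within 22000 nM to 100000 nM.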

Compound 4, half-maximal effective concentration: > 22000 nM
Compound 4 gave a limit, no number; the forecaster's own chance of this, stated with the estimate: 85%; the middle value is on the limit's open side.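

In this assay, going by these compounds alone, compound 4 gives > 22000 nM, a limit and not a number, so no step from compound 4 to compound 1, compound 2 or compound 3 can be read: the limit of > 22000 nM in this assay, at which 4 of the 4 values shown sit. The compounds shown leave open whether any of these groups changes the result in this assay.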